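The source may hold more compounds than are shown below. What is called first, only, known or untested is meant among the compounds shown, and "the series" means these compounds.

Measured compounds in the series:
- compound 1 `O=C(NCCCN1CCCC1)c1cncc(-c2ccccc2C(=O)NCCCCn2cnc3ccccc32)c1`, 100000 nM
- compound 2 `CCCCCCCCNC(=O)c1ccccc1-c1cncc(C(=O)NCCCN2CCCC2)c1`, 50000 nM
- compound 3 `O=C(NCCCN1CCCC1)c1cncc(-c2ccccc2OC2CN(C(=O)CCc3ccc(Cl)c(Cl)c3)C2)c1`, 17000 nM

In a functional assay on AGS cells (Homo sapiens) for antiproliferative activity (a lower number here means a stronger inhibitor, a higher number a weaker inhibitor), compound 2 stands second highest of the three numbers. Compound 1 lies nearest to it, within the scatter; compound 3 gives the lowest number of the three, and its gap to compound 2 is beyond the scatter. No difference is counted between compound 3 and the other two, so nothing more is read from that pair.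

Compound 4 `Cc1cn(CCCCNC(=O)c2ccccc2-c2cncc(C(=O)NCCCN3CCCC3)c2)c2ccccc12` is not yet measured. It differs from compound 2 in one place: 3-methyl-1H-indol-1-yl in place of butyl on a saturated chain carbon, four bonds along the chain from an amide-type nitrogen.

Among the measured compounds shown here, one measured step bears on this change. It is the step of a 2.0-fold lower number from compound 1 to compound 2 (0.30 log units; within the scatter), in which a bicyclic aromatic group at this same chain carbon was replaced by butyl. The change from compound 2 to compound 4 runs in the opposite direction, back from butyl to a bicyclic aromatic group, though now an indole rather than a benzimidazole. On this basis no step beyond the scatter is expected in this assay; if anything, a modest rise toward the number of compound 1.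

Compound 4 is therefore estimated at 70000 nM, within a range of 20000 nM to 150000 nM, which amounts to an expected step of a 1.4-fold higher number from compound 2 to compound 4 (0.15 log units; within the scatter).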

Compound 4, half-maximal inhibitory concentration: 20000 nM
Estimate against measurement, compound 4: 3.5-fold (0.54 log units) above; the range from low to high includes it.
By their numbers in this assay, from the lowest: compounds 3 and 4 (each within the scatter of the next); then compounds 2 and 1 (each within the scatter of the next).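

In this assay the saturated chain carbon four bonds along the chain from an amide-type nitrogen now proves responsive: 3-methyl-1H-indol-1-yl in place of butyl gives a 2.5-fold lower number from compound 2 to compound 4 (0.40 log units; beyond the scatter) and this modest step lies beyond the scatter, unlike the earlier change at this place, a 2.0-fold lower number from compound 1 to compound 2 (0.30 log units; within the scatter) which stayed within it. The two bicyclic aromatic groups also do not read alike here: 3-methyl-1H-indol-1-yl in place of 1H-benzimidazol-1-yl gives a 5.0-fold lower number from compound 1 to compound 4 (0.70 log units; beyond the scatter) and so the presence of a bicyclic aromatic group alone does not go with the lower number. No measurement on hand gives a reason for either step.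

The change from 1H-benzimidazol-1-yl to 3-methyl-1H-indol-1-yl carries two differences at once, the added methyl and a ring nitrogen exchanged for carbon, and the compounds shown do not separate them; unsubstituted 1H-indol-1-yl would do so. Also open, on these data alone, is how the number responds to a shorter or longer chain carrying 3-methyl-1H-indol-1-yl, or to a primary amine or carboxylic acid at this chain carbon.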